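This account rests on a few compounds, and the source may have more. Where it says the series, first, only, none or still open, it means among the compounds named here.

Of the compounds shown here, three have been measured in an assay for inhibition of Tryptophan 2,3-dioxygenase (Homo sapiens), with stated times of 10 min and 60 min, tested at 100 uM; on this read-out lower numbers stand for a weaker effect and higher numbers for a stronger effect at the one concentration tested. Compound 1 `Oc1ccc(CNc2cc(C(F)(F)F)cc3[nH]ncc23)cc1` gives 91%. Compound 2 `O=[N+]([O-])c1ccccc1CNc1cccc2[nH]ncc12` gives 87%. Compound 3 `NCCn1ncc2c(NCc3ccccc3[N+](=O)[O-])cc(C(F)(F)F)cc21` gives 29%. Compound 2 stands second of the three numbers: its value lies within the usual scatter of that of compound 1, so the two cannot be told apart, while it lies far beyond the scatter above that of compound 3.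

Compound 4 `N#Cc1cc(NCc2ccccc2[N+](=O)[O-])c2cn[nH]c2c1` has not yet been measured. It differs from compound 2 in one place: cyano in place of hydrogen on an aromatic carbon. Among the measured compounds shown here, no step between two measured compounds matches this change, so there is no direct template for it. Compound 1, which carries a trifluoromethyl group on its core, gives 91%, and that value shows that a substituent on this ring can go with high inhibition in this assay. The step of a number 7 percentage points lower from compound 2 to compound 4 (within the scatter) is therefore expected to be small, and in no direction beyond the scatter. Compound 4 is estimated at 80%, with a range from 55% to 95%.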

Compound 4, a percentage reported as inhibition, at one concentration (the size of the read-out at that concentration, not a potency): 41%
The estimate for compound 4 lay 39 percentage points above the measured number; measured number outside the range, below it.
By their numbers in this assay, from the lowest: compound 3; then compound 4; then compounds 2 and 1 (each within the scatter of the next).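

In this assay, putting a cyano group on this aromatic carbon of the core of compound 2 goes with a number 46 percentage points lower from compound 2 to compound 4 (beyond the scatter), so this position is not indifferent to what it carries. Compound 1 keeps high inhibition with a trifluoromethyl group on its core, but it differs from compound 4 in more than one place, so it could not show how a substituent alone behaves here. Nothing in the data explains this loss of inhibition.

One step cannot tell whether the drop belongs to the cyano group in particular or would come with any substituent on this carbon. A methyl group, a chlorine atom or a methoxy group in the same place, with the rest of compound 2 unchanged, would help separate these two readings.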